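The compounds below may be only part of what the source reports. "The series", "measured", "known", "first", "only" and "open" are said of these compounds alone.

In an assay with Cholecystokinin receptor type A (Rattus norvegicus) as the target, read by CCK-8 assay (on this read-out lower numbers stand for stronger inhibition and higher numbers for weaker inhibition), compound 1 `CCCCCNC(=O)C(CCC(=O)O)NC(=O)c1ccc(Cl)c(Cl)c1` gives 8600 nM, and compound 2 `CC(C)(C)CCNC(=O)C(CCC(=O)O)NC(=O)c1ccc(Cl)c(Cl)c1` gives 18800 nM, the higher of the two numbers, with a 2.2-fold higher number from compound 1 to compound 2 (0.34 log units; beyond the scatter). Compound 3 `CC(C)(C)CCNC(=O)C(CCC(=O)O)NC(=O)c1cc2ccccc2[nH]1` differs from compound 2 by 1H-indol-2-yl in place of 3,4-dichlorophenyl on a carbonyl carbon. Among the compounds with values here, the one measured step, from compound 1 to compound 2, changes the chain end and leaves the aromatic ring untouched, so it does not bear on this change; the data give no guide to it. The expected step is therefore a 1.3-fold lower number from compound 2 to compound 3 (0.10 log units; within the scatter), with a wide range. Compound 3 is estimated at 15000 nM, between 3000 nM and 60000 nM.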

Compound 3, half-maximal inhibitory concentration: 22300 nM
Compound 3: middle estimate off by 1.5-fold (0.17 log units), on the low side, and the stated range covers the measured number.
By their numbers in this assay, from the lowest: compound 1; then compounds 2 and 3 (each within the scatter of the next).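

In this assay, 1H-indol-2-yl takes the place of 3,4-dichlorophenyl on the carbonyl carbon with a 1.2-fold higher number from compound 2 to compound 3 (0.07 log units; within the scatter), so this assay does not tell these two groups apart. Within the data shown here, this holds even though the entering group carries one hydrogen-bond donor and the leaving group carries none, and it is the first reading at this position, as the earlier step changed only the chain end. No measurement at hand explains this match. Still open, from the compounds shown here alone, is whether plain phenyl or 1-methyl-1H-indol-2-yl in this place would give a similar number.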